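The source may hold more compounds than are shown below. What is called first, only, known or untested is meant among the compounds shown, and "the series" means these compounds.

Compound 1 `C=CCSc1nncc2cnc(-c3ccccc3)n12` — > 48000 nM (a limit)
Compound 2 `Oc1nncc2cnc(-c3ccccc3)n12` — > 48000 nM (a limit)
Compound 3 `Cc1nc(-c2ccccc2)n2c(O)nncc12` — > 48000 nM (a limit)

In a functional assay for inhibition, with Homo sapiens as the target (on this read-out higher numbers stand for weaker inhibition and lower numbers for stronger inhibition), compound 1 gives > 48000 nM, a limit of the assay rather than a number. Compound 2 gives > 48000 nM, again a limit. Compound 3 gives > 48000 nM, also a limit. Compound 3 therefore stands where every measured compound stands, at the limit of > 48000 nM in this assay, at which 3 of the 3 values shown sit, so a step that the two limits leave unreadable from compound 1 to compound 2 and a step that the two limits leave unreadable from compound 2 to compound 3 cannot be read as steps of any size.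

Compound 4 `C=CCSc1nncc2c(C)nc(-c3ccccc3)n12` differs from compound 3 by allylsulfanyl in place of hydroxy on an aromatic carbon, reversing the change that went from compound 1 to compound 2. Nothing measured shows either group moving a compound off the limit. Compound 4 is expected to sit near 100000 nM, between 40000 nM and 400000 nM, most likely reported as a limit again. The expected step that the limit leaves unreadable from compound 3 to compound 4 is estimated to be none beyond the scatter.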

Compound 4, half-maximal inhibitory concentration: > 48000 nM
Compound 4 was reported as a limit; the forecaster's own chance of this, stated with the estimate: 85%; the middle value is on the limit's open side.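

Compound 4 also gives a limit, so neither its step from compound 3 nor its step from compound 1 can be read: the limit of > 48000 nM in this assay, at which 4 of the 4 values shown sit. The compounds shown leave open whether in this assay hydroxy, allylsulfanyl or methyl changes inhibition at all.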